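Adding a Second Methoxy Group to Compound 2

A few compounds are considered here, and "the series" means these few. Any claim that something is new, unique, unknown or untested is made for them only; others in the source may bear on it.

Two compounds of this series carry a measured number. Compound 1 `COc1ccc(-c2cc(C(=O)Nc3nc4ccc(Cl)cc4s3)nc3cc(-c4ccccc4)nn23)cc1OC` gives 6910 nM in a functional assay on MCF7 cells (Homo sapiens) for cytotoxicity, read by MTT assay, with a stated time of 48 h (on this read-out lower numbers stand for stronger inhibition and higher numbers for weaker inhibition), while compound 2 `COc1ccc(-c2cc(C(=O)Nc3nc4ccccc4s3)nc3cc(-c4ccccc4)nn23)cc1` gives 2230 nM in this assay and so stands at the lower of the two numbers, with compound 1 above it by more than the scatter. Compound 1 and compound 2 differ in two places at once, so the two values alone cannot say what each change contributes. Compound 3 `COc1ccc(-c2cc(C(=O)Nc3nc4ccccc4s3)nc3cc(-c4ccccc4)nn23)cc1OC` has not yet been measured. It differs from compound 2 by methoxy in place of hydrogen on an aromatic carbon. Among the compounds with values here, because the higher number of compound 1 6910 nM is the only guide, a modest step toward a higher number, or none beyond the scatter, is expected for compound 3. The estimated step of a 1.8-fold higher number from compound 2 to compound 3 (0.25 log units; within the scatter) expresses this. Compound 3 is thus expected to give about 4000 nM in this assay, within a range from 1800 nM to 9000 nM.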

Compound 3, half-maximal inhibitory concentration: 14700 nM
The estimate for compound 3 lay 3.7-fold (0.57 log units) below the measured number; the whole stated range lies below it.
By their numbers in this assay, from the lowest: compound 2; then compound 1; then compound 3.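

In this assay, going from 4-methoxyphenyl to 3,4-dimethoxyphenyl, with the new methoxy ortho to a methoxy group, gives a 6.6-fold higher number from compound 2 to compound 3 (0.82 log units; beyond the scatter), a clear loss at this position when the rest of the structure is unchanged. With the 3,4-dimethoxyphenyl kept, hydrogen in place of chloro on an aromatic carbon gives a 2.1-fold higher number from compound 1 to compound 3 (0.33 log units; beyond the scatter), so the two changes that were mixed in the first pair can now be read apart, and they run in opposite directions, with the added methoxy raising the number and the loss of chloro also raising it. No measurement here explains either step.

On these data alone, it remains open whether a hydroxyl, an amine or a longer ether chain at the same place would raise the number as methoxy does. As far as these compounds go, it is also open whether chloro would lower the number to a similar degree alongside the 4-methoxyphenyl.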